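Working notes: amide methyl step on two aryl cores

The source may report more compounds than this note shows. Statements on the series, on what has been measured and on what is new or still open speak of the compounds shown alone.

Compound 1 `CCNC(=O)C1=C(C)NC(=O)NC1c1ccco1` is the reference point of this small set. In an assay on membranes from HEK293 cells for displacement of a labelled ligand from adenosine receptor A2b (Homo sapiens), read by scintillation counting, with a stated time of 30 min, tested at 1 uM (a lower number here means less inhibition, a higher number more inhibition at the concentration tested (going by the name of the read-out)), compound 1 gives 1%. Compound 2 `CC1=C(C(=O)NC(C)C)C(c2ccco2)NC(=O)N1` differs from compound 1 by methyl in place of hydrogen on a saturated chain carbon bound to an amide-type nitrogen and a saturated chain carbon; in this assay compound 2 gives 2%, and the step is a number 1 percentage points higher from compound 1 to compound 2 (within the scatter). Compound 3 `CCNC(=O)C1=C(C)NC(=O)NC1c1ccsc1` differs from compound 1 at the aryl group; this difference, which is also how the two cores carrying the amide change discussed below differ from each other, is thiophen-3-yl in place of furan-2-yl on a saturated ring carbon. In this assay compound 3 gives 1%, so that no change at the digits printed from compound 1 to compound 3 (within the scatter). All three numbers sit together at the low end of what this assay reports, and none of the steps among them reaches beyond the usual scatter.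

Compound 4 `CC1=C(C(=O)NC(C)C)C(c2ccsc2)NC(=O)N1` has not yet been measured. It differs from compound 3 by methyl in place of hydrogen on a saturated chain carbon bound to an amide-type nitrogen and a saturated chain carbon. For the measured compounds named here, this is the same change as the one made from compound 1 to compound 2, at the same place, here on the core of compound 3 rather than the core of compound 1. Going by the values given here, with only one earlier instance, nothing shows that the aryl group alters how the amide change plays out.

The step expected in this assay is a number 1 percentage points higher from compound 3 to compound 4 (within the scatter), resting on the earlier step being a number 1 percentage points higher from compound 1 to compound 2 (within the scatter) and on compound 3 starting at 1%. Compound 4 is estimated at 2%, with an expected range from 0% to 9%.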

Compound 4, a percentage reported as inhibition, at one concentration (the size of the read-out at that concentration, not a potency): 3%
For compound 4 the middle estimate is 1 percentage points below the measured one; the measured number falls inside the stated range.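

Working across both cores, the ethyl to isopropyl change on the core of compound 3 in this assay reads as a number 2 percentage points higher from compound 3 to compound 4 (within the scatter), and it agrees with the same change on the core of compound 1: the same change on two cores in this assay, a number 1 percentage points higher (within the scatter) from compound 1 to compound 2 and a number 2 percentage points higher (within the scatter) from compound 3 to compound 4, 1 percentage points apart, within the scatter of two such steps. The exchange of furan-2-yl for thiophen-3-yl, read on the isopropyl amides, is a number 1 percentage points higher from compound 2 to compound 4 (within the scatter), and it agrees with the same exchange on the ethyl amides: the same change on two cores in this assay, no change at the digits printed (within the scatter) from compound 1 to compound 3 and a number 1 percentage points higher (within the scatter) from compound 2 to compound 4, 1 percentage points apart, within the scatter of two such steps. For the compounds shown here, this shows that both changes carry from one core to the other without a detectable difference, but all four compounds sit at the low end of what this read-out reports and no step reaches beyond the scatter, so the agreement is between steps that cannot be told from no step at all, and it does not show that either change has an effect to transfer.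

Open, going by these compounds, is whether a longer chain, a cycloalkyl group or a chain bearing an amine or a carboxylic acid in place of the ethyl or isopropyl, or a phenyl ring in place of furan-2-yl or thiophen-3-yl, would move the number beyond the scatter. Only on such a compound could the transfer of a step be tested at a level clear of the scatter.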